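This account rests on a few compounds, and the source may have more. Where it says the series, first, only, none or still open, it means among the compounds named here.

Measured compounds in a physicochemical assay for lipophilicity, using the shake flask method, in phosphate buffer, measured as octanol-water partition, at pH 7.4; a higher number here means a more lipophilic compound, a lower number a more polar compound:
compound 1, `COc1cc(-c2cc(C(=O)O)c3ccccc3n2)ccc1OCC(=O)Nc1ccccc1C`: 0.8
compound 2, `COc1cc(-c2cc(C(=O)O)c3ccccc3n2)ccc1OCC(=O)Nc1ccccc1C(F)(F)F`: 1.3

Within the data shown here, compound 2 stands highest of the two numbers, with compound 1 as its only neighbour, a step of a number 0.50 log units higher from compound 1 to compound 2 (beyond the scatter) separating them. Compound 3, `COc1cc(-c2cc(C(=O)O)c3ccccc3n2)ccc1OCC(=O)NCc1cccs1`, differs from compound 2 by (thiophen-2-yl)methyl in place of 2-(trifluoromethyl)phenyl on an amide-type nitrogen. Among the measured compounds shown here, the one measured step, trifluoromethyl against methyl on the aromatic ring, bears on the change only insofar as the trifluoromethyl that gave the higher number is removed; no measured pair covers the exchange of the whole amide substituent. A modest decrease is therefore expected, about a number 0.70 log units lower from compound 2 to compound 3 (beyond the scatter). Compound 3 is estimated at 0.6, within 0.1 to 1.1.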

Compound 3, distribution coefficient: 0
Beside the measured number, compound 3's estimate is 0.60 log units above it; the whole stated range lies above it.
By their numbers in this assay, from the lowest: compound 3; then compound 1; then compound 2.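

In this assay, the substituent on the amide-type nitrogen proves able to move the number further than the methyl and trifluoromethyl exchange did: (thiophen-2-yl)methyl gives a number 1.30 log units lower from compound 2 to compound 3 (beyond the scatter) in place of 2-(trifluoromethyl)phenyl, and a number 0.80 log units lower from compound 1 to compound 3 (beyond the scatter) in place of 2-methylphenyl. Both exchanges run the same way, the first large and the second modest, and no compound shown goes against that direction. Nothing shown gives a reason for these steps.

From the compounds shown here alone, whether the five-membered aromatic ring or the added carbon link carries the change remains open. A benzyl group on that nitrogen would separate the two, and a methyl ester in place of the carboxylic acid is also not among the compounds shown.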